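The source may report more compounds than this note shows. Statements on the series, on what has been measured and on what is new or still open speak of the compounds shown alone.

Measured compounds:
compound 1 `N#CC1(NC(=O)[C@@H](CC(=O)N2CCOCC2)CC2CCCCC2)CC1` with 12 nM
compound 2 `N#C[C@@]1(NC(=O)[C@@H](CC(=O)N2CCOCC2)CC2CCC(c3ccccc3)CC2)CCN(C2CCCCC2)C1` with "not determined" (no result reported)

Compound 1 gives 12 nM in an assay on isolated protein for inhibition of cathepsin S (Homo sapiens) (on this read-out higher numbers stand for weaker binding and lower numbers for tighter binding), the only number shown, so its standing cannot be ranked against anything else. Compound 3 `CN1CCC(C#N)(NC(=O)[C@@H](CC(=O)N2CCOCC2)CC2CCCCC2)CC1` differs from it by 4-cyano-1-methylpiperidin-4-yl in place of 1-cyanocyclopropyl on an amide-type nitrogen. For the measured compounds named here, no measured pair shows this change, and without such a step the direction is open, though the new group is larger and a modest loss of binding is a plausible expectation. Compound 3 is therefore expected to give 40 nM, within 8 nM to 200 nM, meaning an estimated step of a 3.3-fold higher number from compound 1 to compound 3 (0.52 log units; beyond the scatter) somewhat beyond the usual scatter.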

Compound 3, dissociation constant: 177 nM
The estimate for compound 3 lay 4.4-fold (0.65 log units) below the measured number, and the stated range covers the measured number.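

In this assay the change from 1-cyanocyclopropyl to 4-cyano-1-methylpiperidin-4-yl on the amide-type nitrogen gives a 15-fold higher number from compound 1 to compound 3 (1.17 log units; beyond the scatter) and provides the first measured sign that binding is sensitive to the group at this place. Nothing shown accounts for the size of this step.

The single step enlarges the ring and adds a methyl-bearing ring nitrogen together, and the compounds shown do not separate the two. On these data alone, how a 1-cyanocyclohexyl group or a 4-cyanopiperidin-4-yl group without the methyl would read here remains open.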